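Halogen swap on the phenyl group: step to compound 4

The source may report more compounds than this note shows. Statements on the series, on what has been measured and on what is new or still open speak of the compounds shown alone.

The series keeps one core and varies the aryl group on an amine nitrogen. In a functional assay, with a stated time of 6 min (on this read-out higher numbers stand for weaker inhibition and lower numbers for stronger inhibition), compound 1 (`S=c1oc(-c2ccc3c(c2)OCCO3)nn1CNc1ccccc1`) gives 5140 nM, compound 2 (`Fc1ccccc1NCn1nc(-c2ccc3c(c2)OCCO3)oc1=S`) gives 6390 nM and compound 3 (`Fc1cc(NCn2nc(-c3ccc4c(c3)OCCO4)oc2=S)cc(F)c1F`) gives 2920 nM. Compound 3 separates only from compound 2: a 2.2-fold lower number from compound 2 to compound 3 (0.34 log units; beyond the scatter) is a modest step, while a 1.8-fold lower number from compound 1 to compound 3 (0.25 log units; within the scatter) stays within the scatter.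

Compound 4 (`S=c1oc(-c2ccc3c(c2)OCCO3)nn1CNc1cc(Cl)ccc1Cl`) carries 2,5-dichlorophenyl in place of 3,4,5-trifluorophenyl on an amine nitrogen. Going by the values given here, no measured step tests chlorine on this ring. The nearest evidence is a 1.2-fold higher number from compound 1 to compound 2 (0.09 log units; within the scatter), together with the two steps to compound 3, and all of these are small. A step beyond the scatter in this assay is therefore not expected, with any drift more likely toward a higher number. The estimated step is a 1.4-fold higher number from compound 3 to compound 4 (0.14 log units; within the scatter). For compound 4 the expected value is 4000 nM, with an estimated range of 1800 nM to 9000 nM.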

Compound 4, half-maximal inhibitory concentration: 5420 nM
Estimate against measurement, compound 4: 1.4-fold (0.13 log units) below; low and high end bracket the measured number.
By their numbers in this assay, from the lowest: compounds 3, 1, 4 and 2 (each within the scatter of the next, the first and the last beyond it).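

In this assay, going by these compounds alone, the first chlorine-bearing aryl group on the amine nitrogen cannot be told apart from any earlier aryl group: the three steps read (a 1.9-fold higher number from compound 3 to compound 4 (0.27 log units; within the scatter)), (a 1.2-fold lower number from compound 2 to compound 4 (0.07 log units; within the scatter)) and (a 1.1-fold higher number from compound 1 to compound 4 (0.02 log units; within the scatter)), each within the scatter. Within the data shown here, compound 4 therefore sits with both the phenyl and the fluorinated compounds, and the step (a 2.2-fold lower number from compound 2 to compound 3 (0.34 log units; beyond the scatter)) remains the only single step beyond the scatter, a modest one. No available evidence bears on this flat response.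

Since 2,5-dichlorophenyl differs from the other aryl groups in both halogen and substitution pattern, the effect of chlorine alone stays unresolved. Also open, from the compounds shown here alone, is whether a methoxy group or a carboxylic acid on the phenyl ring, or a saturated chain in place of that ring, would move the number beyond the scatter.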